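The compounds below may be only part of what the source reports. "The series", "measured", "known", "first", "only" and "open" are said of these compounds alone.

Three compounds share one amide core carrying a trifluoromethylphenyl group. Compound 1 `COc1ccccc1C1CCCN1C(=O)C(Nc1ccccc1)c1ccc(C(F)(F)F)cc1` gives 33 nM in an assay on HEK293 cells for antagonist activity at transient receptor potential M8 protein (Canis lupus familiaris), read by fluorescence and calcium flux, with a stated time of 5 min (on this read-out higher numbers stand for weaker inhibition and lower numbers for stronger inhibition), the lowest of the three numbers. Compound 3 `O=C(C(Nc1ccc(F)cc1)c1ccc(C(F)(F)F)cc1)N1CCCC1c1ccccc1Cl` gives 73 nM, a higher number beyond the scatter, and compound 2 `O=C(C(Nc1ccccc1)c1ccc(C(F)(F)F)cc1)N1CCC[C@@H]1c1ccccc1Cl` gives 168 nM, higher still. Compound 4 `COc1ccccc1C1CCCN1C(=O)C(Nc1ccccc1F)c1ccc(C(F)(F)F)cc1` has not been measured. It differs from compound 1 in one place: fluoro in place of hydrogen on an aromatic carbon. Within the data shown here, no measured pair shows this single change on its own, since compounds 2 and 3 differ from compound 1 in more than one place. A small step is expected, probably within the scatter, with no clear direction. Compound 4 is therefore expected to give about 40 nM, between 15 nM and 110 nM. The expected step of a 1.2-fold higher number from compound 1 to compound 4 (0.08 log units; within the scatter) is small.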

Compound 4, half-maximal inhibitory concentration: 12 nM
For compound 4 the middle estimate is 3.3-fold (0.52 log units) above the measured one; the whole stated range lies above it.
By their numbers in this assay, from the lowest: compound 4; then compound 1; then compound 3; then compound 2.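

Among these compounds, replacing anilino with (2-fluorophenyl)amino in the core of compound 1 is the first single change seen on its own, and in this assay it gives a 2.8-fold lower number from compound 1 to compound 4 (0.44 log units; beyond the scatter). This means that a fluoro on this aromatic carbon, ortho to a large group, is tolerated and gives stronger inhibition, by a step beyond the usual scatter. Nothing shown here explains this gain.

Still open, as far as these compounds go, is whether a different group at this position, such as methyl, chloro or a nitrile, would match fluoro. Also open, from the compounds shown here alone, is whether fluoro elsewhere on this ring would give a similar step.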